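This account rests on a few compounds, and the source may have more. Where it says the series, first, only, none or still open, it means among the compounds named here.

Measured in a functional assay on A549 cells (Homo sapiens) for antiproliferative activity, read by MTT assay, with a stated time of 48 h; a lower number here means a stronger inhibitor, a higher number a weaker inhibitor:
- Compound 1 `C/C(=C\CC/C(C)=C/CC[C@@H]1[C@@]2(C)CCC(=O)C(C)(C)[C@H]2CC[C@@]1(C)O)CC/C=C(\C)C(=O)OCc1cn(-c2cccc([N+](=O)[O-])c2)nn1`: > 150000 nM
- Compound 2 `C/C(=C\CC/C(C)=C/CC[C@@H]1[C@@]2(C)CCC(=O)C(C)(C)[C@H]2CC[C@@]1(C)O)CC/C=C(\C)C(=O)OCc1cn(-c2cccc(Cl)c2)nn1`: 147000 nM

Within the data shown here, compound 2 at 147000 nM holds the only actual number so far. Compound 1 gives > 150000 nM, which is a limit of the assay and not a number.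

Compound 3 `C/C(=C\CC/C(C)=C/CC[C@@H]1[C@@]2(C)CCC(=O)C(C)(C)[C@H]2CC[C@@]1(C)O)CC/C=C(\C)C(=O)OCc1cn(-c2ccccc2)nn1` has hydrogen in place of chloro on an aromatic carbon. Among the measured compounds shown here, one measured step bears on this, a swap of chloro in place of nitro on an aromatic carbon: an at least 1.0-fold lower number from compound 1 to compound 2 (0.00 log units; that floor lies within the scatter). It offers only a floor within the scatter, so no step beyond the scatter is expected in this assay. The expected step is a 1.0-fold lower number from compound 2 to compound 3 (0.01 log units; within the scatter). The estimate for compound 3 is 145000 nM, within a range of 70000 nM to 280000 nM.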

Compound 3, half-maximal inhibitory concentration: > 150000 nM
Compound 3: a limit, no number; the forecaster's own chance of this, stated with the estimate: 40%; middle value at least 1.0-fold (0.01 log units) from the limit.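

Going from 3-chlorophenyl to phenyl in this assay gives an at least 1.0-fold higher number from compound 2 to compound 3 (0.00 log units; that floor lies within the scatter), so hydrogen at this place on the ring brings no step that can be told apart from the scatter. Compound 3 gives > 150000 nM, a limit of the assay and not a number. The step from compound 1 to compound 3 cannot be read, and the set presses against a single ceiling: the limit of > 150000 nM in this assay, at which 2 of the 3 values shown sit.

As far as these compounds go, whether an amine or a carboxylic acid at this place would give a clearly lower number stays open. So does whether any change on this ring can matter while the shared core stays the same.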